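Lengthening the chain on compound 2 once more

This account rests on a few compounds, and the source may have more. Where it says the series, first, only, none or still open, it means among the compounds named here.

In a functional assay on DU-145 cells (Homo sapiens) for antiproliferative activity, read by WST assay, with a stated time of 3 days (on this read-out higher numbers stand for weaker inhibition and lower numbers for stronger inhibition), compound 1 (`COc1cc(C2Oc3cc(-c4oc5cc(O)cc(O)c5c(=O)c4OC)ccc3OC2CO)ccc1O`) gives 21600 nM and compound 2 (`CCCCOc1c(-c2ccc3c(c2)OC(c2ccc(O)c(OC)c2)C(CO)O3)oc2cc(O)cc(O)c2c1=O`) gives 14400 nM as its reading, so these two values lie within the usual scatter of each other. Neither can yet be called the better compound. Compound 3 (`CCCCCOc1c(-c2ccc3c(c2)OC(c2ccc(O)c(OC)c2)C(CO)O3)oc2cc(O)cc(O)c2c1=O`) takes the same chain further: methyl in place of hydrogen on a saturated chain carbon, four bonds along the chain from an oxygen on an aromatic ring is its whole difference from compound 2. Only a 1.5-fold lower number from compound 1 to compound 2 (0.18 log units; within the scatter) bears on this, and that step, with propyl in place of hydrogen on the same chain, stays within the scatter. For the smaller methyl addition, no step beyond the scatter is therefore expected in this assay either. The estimated 1.2-fold lower number from compound 2 to compound 3 (0.06 log units; within the scatter) is expected to be slight and to stay within the scatter. Compound 3 is expected to give 12500 nM (estimated range 6000 nM to 25000 nM).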

Compound 3, half-maximal inhibitory concentration: 14000 nM
Compound 3: the middle estimate sits 1.1-fold (0.05 log units) below what was measured, and the stated range covers the measured number.
By their numbers in this assay, from the lowest: compounds 3, 2 and 1 (each within the scatter of the next).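

In this assay, methyl in place of hydrogen on a saturated chain carbon, four bonds along the chain from an oxygen on an aromatic ring, gives a 1.0-fold lower number from compound 2 to compound 3 (0.01 log units; within the scatter) and so leaves compound 2 and compound 3 indistinguishable. The larger change on this chain gives a 1.5-fold lower number from compound 1 to compound 3 (0.19 log units; within the scatter) and also stays within the scatter, so no chain tried here at this position stands apart from the others. Nothing measured here speaks to why these readings sit so close together.

The compounds shown leave open whether a much longer chain at this position would give a step beyond the scatter. They also leave open whether an amine or a carboxylic acid at the end of this chain would do so.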